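Methylating the Sulfonamide Nitrogen of Compound 1

The source may hold more compounds than are shown below. What is called first, only, known or untested is meant among the compounds shown, and "the series" means these compounds.

Three compounds have been measured in a functional assay on HeLa cells (Homo sapiens) for antiproliferative activity, read by CCK-8 assay, with a stated time of 72 h; on this read-out higher numbers stand for weaker inhibition of growth and lower numbers for stronger inhibition of growth:

Compound 1, `CC[C@@H]1C(=O)N(C)c2cnc(Nc3ccc(S(N)(=O)=O)cc3)nc2N1C1CCCC1`, gives 317 nM.
Compound 2, `CC[C@@H]1C(=O)N(C)c2cnc(-n3ccc4cc(C(=O)NCC(C)C)ccc43)nc2N1C1CCCC1`, gives 3280 nM.
Compound 3, `CCCNC(=O)c1ccc2c(ccn2-c2ncc3c(n2)N(C2CCCC2)[C@H](CC)C(=O)N3C)c1`, gives 238 nM.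

Compound 1 stands second highest of the three numbers. Its nearest neighbour is compound 3, whose value lies within the scatter of compound 1, so the two cannot be ordered. Compound 2 stands well apart, with a number beyond the scatter above compound 1.

Compound 4, `CC[C@@H]1C(=O)N(C)c2cnc(Nc3ccc(S(=O)(=O)NC)cc3)nc2N1C1CCCC1`, differs from compound 1 in one place: methyl in place of hydrogen on a sulfonamide nitrogen. Cut one bond further out, the change reads sulfamoyl to methylsulfamoyl.

Going by the values given here, only one measured step exists, a 14-fold lower number from compound 2 to compound 3 (1.14 log units; beyond the scatter), and it concerns a methyl on a saturated chain carbon in a different part of a different compound, so it does not bear on the change at the sulfonamide nitrogen. Nothing measured here speaks to that nitrogen. The step is therefore expected to stay within the scatter, a 1.3-fold higher number from compound 1 to compound 4 (0.12 log units; within the scatter). Compound 4 is estimated at 420 nM, with a range from 150 nM to 1200 nM.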

Compound 4, concentration for 50% growth inhibition: 148 nM
Compound 4: middle estimate off by 2.8-fold (0.45 log units), on the high side, and the stated range ends above it.
By their numbers in this assay, from the lowest: compounds 4, 3 and 1 (each within the scatter of the next, the first and the last beyond it); then compound 2.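

In this assay the sulfonamide nitrogen of compound 1 accepts methyl in place of hydrogen, and the change gives a 2.1-fold lower number from compound 1 to compound 4 (0.33 log units; beyond the scatter) as a modest step towards stronger inhibition of growth. Going by these compounds alone, this is the first measured step at this position, and it shows that the sulfamoyl group can carry a small substituent on its nitrogen without any loss of growth inhibition on this read-out. Nothing in the available data offers a reason for the gain.

Going by these compounds, a single methyl cannot show whether the trend continues, so it remains open whether an ethyl or a longer chain on this nitrogen, or a second methyl on it, would lower the number further or reverse the step. On these data alone, it is also open whether a carboxylic acid or an amine could replace the whole sulfamoyl group.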